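This account rests on a few compounds, and the source may have more. Where it says the series, first, only, none or still open, it means among the compounds named here.

Compound 1 `CC(C)=CCC/C(C)=C/CC1Cc2c(OCCCNC(=O)c3ccco3)cc(=O)n(CCCO)c2CC1(C)C`: 5200 nM
Compound 2 `CC(C)=CCC/C(C)=C/CC1Cc2c(OCCCNC(=O)c3cccs3)cc(=O)n(CCCO)c2CC1(C)C`: 4900 nM

In a functional assay on PANC-1 cells (Homo sapiens) for inhibition, read by MTT assay, with a stated time of 24 h (a higher number here means a weaker inhibitor, a lower number a stronger inhibitor), compound 2 sits level with compound 1, the two lying within the scatter of repeated measurements. Compound 3 `COc1ccc(NC(=O)Oc2cc(=O)n(CCCO)c3c2CC(C/C=C(\C)CCC=C(C)C)C(C)(C)C3)cc1` brings a bigger change: (4-methoxyphenyl)carbamoyl in place of 3-(((thiophen-2-yl)carbonyl)amino)propyl on an oxygen on an aromatic ring. Here (4-methoxyphenyl)carbamoyl stands in place of 3-(((thiophen-2-yl)carbonyl)amino)propyl on an oxygen on an aromatic ring. Going by the values given here, the only measured step, a 1.1-fold lower number from compound 1 to compound 2 (0.03 log units; within the scatter), put thiophen-2-yl in place of furan-2-yl, so it says little about replacing the whole group. No clear direction can be expected, and the expected step, a 1.2-fold higher number from compound 2 to compound 3 (0.09 log units; within the scatter), stays within the scatter, though with wide uncertainty. Compound 3 is estimated at 6000 nM, with a range of 2000 nM to 20000 nM.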

Compound 3, half-maximal inhibitory concentration: 7100 nM
Compound 3: the middle estimate sits 1.2-fold (0.07 log units) below what was measured, and the stated range covers the measured number.
By their numbers in this assay, from the lowest: compounds 2, 1 and 3 (each within the scatter of the next).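

Changes at this position are no longer limited to the end ring: in this assay, replacing the whole group on an oxygen on an aromatic ring gives a 1.4-fold higher number from compound 2 to compound 3 (0.16 log units; within the scatter) and a 1.4-fold higher number from compound 1 to compound 3 (0.14 log units; within the scatter). Going by these compounds alone, both steps lie within the scatter, so the whole-group exchange gives a reading level with the earlier compounds, just as the smaller furan-2-yl to thiophen-2-yl exchange did. No evidence here explains this outcome. Still open, as far as these compounds go, is whether a free amine, a carboxylic acid or a longer chain on this oxygen would give a step beyond the scatter.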